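A few compounds are considered here, and "the series" means these few. Any claim that something is new, unique, unknown or untested is made for them only; others in the source may bear on it.

Compound 2 `COc1cc(NC(=O)Nc2cc(Nc3ccc(C)c(F)c3)ncn2)cc(OC)c1` is the point of departure. In a functional assay on HCC827 cells (Homo sapiens) for inhibition, read by MTT assay, with a stated time of 48 h, tested at 10 uM (a lower number here means less inhibition, a higher number more inhibition at the concentration tested (going by the name of the read-out)), compound 2 gives 72%, and its only companion so far, compound 1 `CCc1ccc(Nc2cc(NC(=O)Nc3cc(OC)cc(OC)c3)ncn2)cc1`, gives 66.2%; the step of a number 5.8 percentage points higher from compound 1 to compound 2 (within the scatter) lies within the scatter, so the two readings cannot be told apart. Compound 3 `COc1cc(NC(=O)Nc2cc(Nc3ccc(Br)cc3OC)ncn2)cc(OC)c1` has not yet been measured in this assay. Its difference from compound 2 is 4-bromo-2-methoxyphenyl in place of 3-fluoro-4-methylphenyl on a nitrogen on an aromatic ring. Going by the values given here, the one measured step that bears on this change, from compound 1 to compound 2, also exchanged one aromatic group on that nitrogen for another and moved the reading by only a number 5.8 percentage points higher from compound 1 to compound 2 (within the scatter). On that single example an exchange of this kind is expected to shift the reading little, with a step of a number 5 percentage points lower from compound 2 to compound 3 (within the scatter) that need not exceed the scatter. Compound 3 is therefore estimated to give about 67% in this assay, between 50% and 82%.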

Compound 3, a percentage reported as inhibition, at one concentration (the size of the read-out at that concentration, not a potency): 57.7%
For compound 3 the middle estimate is 9.3 percentage points above the measured one; low and high end bracket the measured number.
By their numbers in this assay, from the lowest: compounds 3, 1 and 2 (each within the scatter of the next, the first and the last beyond it).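

Going by these compounds alone, at this position, on a nitrogen on an aromatic ring, swapping one aromatic group for another can matter: in this assay, 4-bromo-2-methoxyphenyl in place of 3-fluoro-4-methylphenyl gives a number 14.3 percentage points lower from compound 2 to compound 3 (beyond the scatter) and is the first step here to pass the scatter. Set against 4-ethylphenyl, the same entering group gives a number 8.5 percentage points lower from compound 1 to compound 3 (within the scatter) and so stays within the scatter, which means only the comparison with compound 2 separates the readings. No measurement on hand explains the step.

On these data alone, the bromine and the methoxy arrive together in compound 3, so their separate shares in the step remain unknown. Also open, as far as these compounds go, is how this position would respond to an aromatic ring carrying an amine or a carboxylic acid.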